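Varying the group on the triazole nitrogen

The source may hold more compounds than are shown below. What is called first, only, known or untested is meant among the compounds shown, and "the series" means these compounds.

Of the compounds shown here, three of the shared core have been measured in a functional assay on NCI-H460 cells (Homo sapiens) for antiproliferative activity, read by sulforhodamine B assay, with a stated time of 72 h; on this read-out lower numbers stand for stronger inhibition and higher numbers for weaker inhibition. Compound 1 `C#CCNCCN(C)CCNc1ccnc2cc(Cl)ccc12` gives 69000 nM. Compound 2 `CN(CCNCc1cn(-c2ccccc2Cl)nn1)CCNc1ccnc2cc(Cl)ccc12` gives 20000 nM, and compound 3 `CN(CCNCc1cn(Cc2ccccc2)nn1)CCNc1ccnc2cc(Cl)ccc12` gives 32000 nM. Compound 3 therefore stands second highest of the three numbers: its nearest neighbour is compound 2, a difference within the scatter, while compound 1 lies beyond the scatter above it. Among the compounds with values here, the only single-point step measured so far, a 1.6-fold higher number from compound 2 to compound 3 (0.20 log units; within the scatter), changed the group on the aromatic nitrogen and stayed within the scatter.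

The next compound, compound 4 `CN(CCNCc1cn(CCC(=O)Nc2ccccn2)nn1)CCNc1ccnc2cc(Cl)ccc12`, differs from compound 3 by ((pyridin-2-yl)carbamoyl)methyl in place of phenyl on a saturated chain carbon bound to an aromatic nitrogen. Cut one bond further out, the same change reads benzyl to 2-((pyridin-2-yl)carbamoyl)ethyl. Within the data shown here, the one step that bears on it is the swap at the same aromatic nitrogen, a 1.6-fold higher number from compound 2 to compound 3 (0.20 log units; within the scatter), which was within the scatter, so no step beyond the scatter is expected in this assay. Compound 4 is expected to give 30000 nM, between 12000 nM and 80000 nM, an estimated step of a 1.1-fold lower number from compound 3 to compound 4 (0.03 log units; within the scatter).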

Compound 4, half-maximal inhibitory concentration: > 200000 nM
Compound 4: a limit, no number (the forecaster's own chance of this, stated with the estimate: 10%); middle value at least 6.6-fold (0.82 log units) from the limit.
By their numbers in this assay, from the lowest: compounds 2 and 3 (each within the scatter of the next); then compound 1. At a limit, above all of these: compound 4.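

In this assay, this position does respond to its substituent: ((pyridin-2-yl)carbamoyl)methyl in place of phenyl on a saturated chain carbon bound to an aromatic nitrogen gives an at least 6.2-fold higher number from compound 3 to compound 4 (0.79 log units; beyond the scatter), whereas the earlier swap at this nitrogen, a 1.6-fold higher number from compound 2 to compound 3 (0.20 log units; within the scatter), stayed within the scatter. Against 2-chlorophenyl on the same aromatic nitrogen, 2-((pyridin-2-yl)carbamoyl)ethyl gives an at least 10-fold higher number from compound 2 to compound 4 (1.00 log units; beyond the scatter), so 2-chlorophenyl and benzyl are accepted alike here, but this group is not. The value of compound 4 is a limit and not a number, and both new steps are lower bounds only: the limit of > 200000 nM in this assay, at which 1 of the 4 values shown sits.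

Compound 4 brings in the longer chain, the amide and the pyridine ring at once, and the compounds shown do not separate these parts. A 2-(phenylcarbamoyl)ethyl group or a chain ending in a carboxylic acid on this nitrogen would help tell them apart.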